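The compounds below may be only part of what the source reports. "The series", "measured", "known", "first", "only" and "open" are said of these compounds alone.

In a functional assay on MDA-MB-231 cells (Homo sapiens) for antiproliferative activity, read by MTT assay, with a stated time of 72 h (a lower number here means a stronger inhibitor, a higher number a weaker inhibitor), three compounds that share one core have been measured so far. Compound 1 `COc1ccc(NC(=O)CCc2cccc3c2B(O)OC3)cc1OC` reached only a limit of the assay, > 100000 nM. Compound 2 `O=C(CCc1cccc2c1B(O)OC2)Nc1cccc(-c2ccc(F)cc2)c1` gives 250 nM, the lower of the two actual numbers, and compound 3 `O=C(CCc1cccc2c1B(O)OC2)Nc1cccc(-c2ccc(OC(F)(F)F)cc2)c1` gives 640 nM.

Compound 4 `O=C(CCc1cccc2c1B(O)OC2)Nc1cccc(-c2cccc(C(F)(F)F)c2)c1` has not yet been measured. It differs from compound 2 in one place: 3-(trifluoromethyl)phenyl in place of 4-fluorophenyl on an aromatic carbon. In short, 3-(trifluoromethyl)phenyl stands in place of 4-fluorophenyl on an aromatic carbon, meta to a large group.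

The nearest guide is the change in compound 3, which also keeps the core and alters the 4-fluorophenyl group: a 2.6-fold higher number from compound 2 to compound 3 (0.41 log units; beyond the scatter). This is a single modest step, so it is a thin basis for prediction. A step of similar size toward a higher number is therefore expected in this assay, with wide uncertainty. The expected change is a 2.0-fold higher number from compound 2 to compound 4 (0.30 log units; within the scatter). The estimate for compound 4 is 500 nM, within an expected range of 180 nM to 1500 nM.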

Compound 4, half-maximal inhibitory concentration: 410 nM
Beside the measured number, compound 4's estimate is 1.2-fold (0.09 log units) above it; the range from low to high includes it.
By their numbers in this assay, from the lowest: compounds 2, 4 and 3 (each within the scatter of the next, the first and the last beyond it). At a limit, above all of these: compound 1.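

Swapping 4-fluorophenyl for 3-(trifluoromethyl)phenyl in this assay gives a 1.6-fold higher number from compound 2 to compound 4 (0.21 log units; within the scatter), so this position accepts a change of both the group on the ring and its place on that ring without a clear shift in the number. The earlier change at this position, a 2.6-fold higher number from compound 2 to compound 3 (0.41 log units; beyond the scatter), did lie beyond the scatter, so the two compounds now show that not every replacement of 4-fluorophenyl here moves the number by a clear margin. Nothing given here accounts for the difference between these two steps.

Compound 4 alters the group and its place at once. A pair such as 3-fluorophenyl and 4-(trifluoromethyl)phenyl would be needed to separate the two. Also open, going by these compounds, is how a ring carrying an amine or a carboxylic acid would behave at this position.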